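Methoxy to isobutyl: a small step expected

This account rests on a few compounds, and the source may have more. Where it says the series, first, only, none or still open, it means among the compounds named here.

Compound 1 `O=C1NCCN1c1ccc(S(=O)(=O)Nc2ccc(C3CCCCC3)cc2)cc1`: > 1000 nM, a limit of the assay
Compound 2 `CCCCOc1ccc(NS(=O)(=O)c2ccc(N3CCNC3=O)cc2)cc1`: 580 nM
Compound 3 `COc1ccc(NS(=O)(=O)c2ccc(N3CCNC3=O)cc2)cc1`: 580 nM

All three were tested in a functional assay on M21 cells (Homo sapiens) for antiproliferative activity, read by sulforhodamine B assay, with a stated time of 48 h; a lower number here means a stronger inhibitor, a higher number a weaker inhibitor. Compound 3 stands level with compound 2, and the reading for compound 1 is a limit, not a number. Compound 4 `CC(C)Cc1ccc(NS(=O)(=O)c2ccc(N3CCNC3=O)cc2)cc1` has isobutyl in place of methoxy on an aromatic carbon. Three measured steps change this same place. no change at the digits printed from compound 2 to compound 3 (within the scatter) is one, while an at least 1.7-fold lower number from compound 1 to compound 2 (0.23 log units; that floor lies within the scatter) and an at least 1.7-fold lower number from compound 1 to compound 3 (0.23 log units; that floor lies within the scatter) are the others. None goes beyond the scatter, so no step beyond the scatter is expected, with a slight lean toward weaker, since isobutyl, like the cyclohexyl of compound 1, holds no oxygen. The expected change is a 1.2-fold higher number from compound 3 to compound 4 (0.08 log units; within the scatter). For compound 4 the estimated value is 700 nM, with an expected range of 280 nM to 1700 nM.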

Compound 4, half-maximal inhibitory concentration: > 1000 nM
Compound 4 was reported as a limit; the forecaster's own chance of this, stated with the estimate: 25%; at least 1.4-fold (0.15 log units) between middle value and limit.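

With isobutyl on this aromatic carbon, the data show an at least 1.7-fold higher number from compound 3 to compound 4 (0.23 log units; that floor lies within the scatter) and an at least 1.7-fold higher number from compound 2 to compound 4 (0.23 log units; that floor lies within the scatter) and neither floor proves a loss beyond the scatter. The step between compound 1 and compound 4 cannot be read. What is new is that the two compounds with an all-carbon group here, isobutyl in compound 4 and cyclohexyl in compound 1, both stop at a limit, while methoxy and butoxy give readable numbers: the limit of > 1000 nM in this assay, at which 2 of the 4 values shown sit.

Going by these compounds, whether the oxygen or the chain matters stays open. A plain butyl chain or an amine at this place could help separate the two.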